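The source may hold more compounds than are shown below. What is called first, only, known or untested is meant among the compounds shown, and "the series" means these compounds.

Compound 3 (`COc1cc(OC)c(C(=O)/C=C/c2ccccc2SC)c(OC)c1`) gives > 20000 nM in an ADME assay on cells (Fibroblast, Homo sapiens) for cytotoxicity, with a stated time of 48 h (a lower number here means a stronger inhibitor, a higher number a weaker inhibitor), which is a limit of the assay and not a number. It thus stands at the limit of > 20000 nM in this assay, at which 2 of the 3 values shown sit. Compound 1 (`COc1cc(O)c(C(=O)/C=C/c2ccc(F)cc2)c(OC)c1`), which also bears 4-fluorophenyl, gives > 20000 nM, likewise a limit. Compound 2 (`COc1cc(OC)c(C(=O)/C=C/c2ccccc2OC)c(OC)c1`) gives a true number of 8200 nM.

The next compound, compound 4 (`COc1cc(OC)c(C(=O)/C=C/c2ccc(F)cc2)c(OC)c1`), has 4-fluorophenyl in place of 2-(methylsulfanyl)phenyl on a double-bonded chain carbon bound to a double-bonded chain carbon. Going by the values given here, only one measured step touches the group that leaves, namely an at least 2.4-fold higher number from compound 2 to compound 3 (0.38 log units; beyond the scatter), with methylsulfanyl in place of methoxy on an aromatic carbon. From the compounds shown here alone, that step is modest and ends at a limit, so its full size is unknown. Among the compounds with values here, no measured step shows what 4-fluorophenyl does on its own. Little change beyond the scatter is therefore expected in this assay, and the number may stay at the limit. The expected step is an at least 1.1-fold lower number from compound 3 to compound 4 (0.07 log units; that floor lies within the scatter). For compound 4 the estimated value is 17000 nM, with an expected range from 7000 nM to 40000 nM.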

Compound 4, half-maximal inhibitory concentration: > 20000 nM
Compound 4: no number, only a limit; the forecaster's own chance of this, stated with the estimate: 55%; middle value at least 1.1-fold (0.07 log units) from the limit.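

Set against 2-methoxyphenyl in this assay, 4-fluorophenyl on this double-bonded chain carbon gives an at least 2.4-fold higher number from compound 2 to compound 4 (0.38 log units; beyond the scatter), so 2-(methylsulfanyl)phenyl is no longer the only group here that moves the number away from that of compound 2. The steps to compound 4 from compound 3 and from compound 1 cannot be read, as both ends of each are limits. Only compound 2 now keeps a true number, and the other compounds share one limit: the limit of > 20000 nM in this assay, at which 3 of the 4 values shown sit.

From the compounds shown here alone, how far compound 1, compound 3 and compound 4 lie past that limit stays open, so neither 4-fluorophenyl against 2-(methylsulfanyl)phenyl nor methyl against hydrogen on the oxygen can be judged. Also open, going by these compounds, is whether a phenyl carrying an amine or a carboxylic acid at this place would give a true number.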